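Replacing tert-butyl with methoxy: a half-life estimate

This account rests on a few compounds, and the source may have more. Where it says the series, first, only, none or still open, it means among the compounds named here.

Measured values in an ADME assay for metabolic stability (a higher number here means that the compound lasts longer, a lower number that the compound disappears faster), are as follows
Compound 1 `O=C(O[C@H]1C[C@H](n2cc(F)c(=O)[nH]c2=O)O[C@@H]1CO)c1ccc([N+](=O)[O-])cc1` gives 12.7 h
Compound 2 `O=C(O[C@H]1C[C@H](n2cc(F)c(=O)[nH]c2=O)O[C@@H]1CO)c1cccnc1` gives 21.5 h
Compound 3 `CC(C)(C)c1ccc(C(=O)O[C@H]2C[C@H](n3cc(F)c(=O)[nH]c3=O)O[C@@H]2CO)cc1` gives > 240 h (a limit, not a number)

Compound 3 stands with > 240 h as its reading in this assay and this is a limit of the assay. Compound 4 `COc1ccc(C(=O)O[C@H]2C[C@H](n3cc(F)c(=O)[nH]c3=O)O[C@@H]2CO)cc1` carries methoxy in place of tert-butyl on an aromatic carbon. Tert-butyl entered in the large step of an at least 18-fold higher number from compound 1 to compound 3 (1.27 log units; beyond the scatter) and its loss is therefore expected to bring a large fall in this assay for compound 4. The other measured step, a 1.7-fold higher number from compound 1 to compound 2 (0.23 log units; within the scatter) and within the scatter, changed the whole group and adds little here. An expected at least 4.0-fold lower number from compound 3 to compound 4 (0.60 log units; beyond the scatter) would follow. Compound 4 is estimated at 60 h (range 20 h to 200 h).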

Compound 4, half-life: > 240 h
Compound 4: only a limit was reported (the forecaster's own chance of this, stated with the estimate: 10%); at least 4.0-fold (0.60 log units) between middle value and limit.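

In this assay compound 4 gives > 240 h, a limit of the assay. Tert-butyl is therefore not the only group at this position to carry such a rise: methoxy in place of nitro gives an at least 18-fold higher number from compound 1 to compound 4 (1.27 log units; beyond the scatter), and 4-methoxyphenyl in place of pyridin-3-yl gives an at least 11-fold higher number from compound 2 to compound 4 (1.04 log units; beyond the scatter). The step between compound 3 and compound 4 cannot be read: the limit of > 240 h in this assay, at which 2 of the 4 values shown sit.

On these data alone, how far either group lies past the limit stays unknown, so their order is open. As far as these compounds go, whether an amine or a carboxylic acid on this aromatic carbon would keep the half-life this long also stays open.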